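Swapping a side chain on a cathepsin S inhibitor

This account rests on a few compounds, and the source may have more. Where it says the series, first, only, none or still open, it means among the compounds named here.

Measured compounds:
compound 1, `Cc1cccc(C(=O)N[C@@H](CC(C)C)C(=O)NCCN2CCc3ccccc32)c1`, 230 nM
compound 2, `COc1cccc(C(=O)N[C@@H](CCC2CCCCC2)C(=O)N[C@H](CN2CCc3cc(F)ccc32)C(C)C)c1`, 14 nM

Of the compounds shown here, two have been measured in an assay on isolated protein for inhibition of cathepsin S (Homo sapiens); on this read-out higher numbers stand for weaker inhibition and lower numbers for stronger inhibition. Compound 1 gives 230 nM, while compound 2 gives 14 nM, the lower of the two numbers, and the gap between them lies beyond the usual scatter of repeated measurements. The two structures differ in several places at once, so no single change can be tied to that gap.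

Compound 3 is `COc1cccc(C(=O)N[C@@H](CCC2CCCCC2)C(=O)N[C@@H](COCc2ccccc2)CN2CCc3cc(F)ccc32)c1`, and it has not yet been measured in this assay. It keeps the whole of compound 2 except for one side chain: (benzyloxy)methyl in place of isopropyl on a saturated chain carbon bound to an amide-type nitrogen and a saturated chain carbon. Within the data shown here, the entering group is larger and brings an extra hydrogen-bond acceptor and an aromatic ring, but nothing among the measured compounds shows how this spot answers to such a change. The expectation is therefore a step of a 1.4-fold higher number from compound 2 to compound 3 (0.15 log units; within the scatter), that is, no movement beyond the scatter, with a wide range to either side. For compound 3 the estimated value in this assay is 20 nM, with a range from 4 nM to 100 nM.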

Compound 3, inhibition constant: 23 nM
Compound 3: middle estimate off by 1.2-fold (0.06 log units), on the low side; measured number inside the range.
By their numbers in this assay, from the lowest: compounds 2 and 3 (each within the scatter of the next); then compound 1.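

In this assay, putting (benzyloxy)methyl in place of isopropyl on a saturated chain carbon bound to an amide-type nitrogen and a saturated chain carbon gives a 1.6-fold higher number from compound 2 to compound 3 (0.22 log units; within the scatter) and so leaves the reading unmoved beyond the scatter. This position therefore accepts a group of 9 heavy atoms, with an aromatic ring and a hydrogen-bond acceptor, in place of a group of 3 heavy atoms with neither, and the number stays in the same range. Compound 1 and compound 2 differ in several places and could not show this, whereas compound 2 and compound 3 differ only here, although nothing available explains why the two groups read alike.

The entering group brings its ring and its oxygen together, so this single pair cannot say whether either part matters on its own, or whether a plain benzyl group would read the same. It also leaves open how the position would answer to a group of a different kind, such as an amine or a carboxylic acid, where the outcome could differ from anything seen with these two uncharged side chains.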